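Halogen swap on the N-aryl ring of the pyrrole series

This account rests on a few compounds, and the source may have more. Where it says the series, first, only, none or still open, it means among the compounds named here.

Measured compounds:
compound 1 `COc1cc(C(=O)c2cn(-c3cccc(Cl)c3)cc2-c2ccccc2)cc(OC)c1OC` gives 150 nM in a functional assay on MCF7 cells (Homo sapiens) for cytotoxicity, read by MTT assay, with a stated time of 96 h; a lower number here means a stronger inhibitor, a higher number a weaker inhibitor
compound 2 `COc1cc(C(=O)c2cn(-c3cccc(Br)c3)cc2-c2ccccc2)cc(OC)c1OC` gives 78 nM in this assay
compound 3 `COc1cc(C(=O)c2cn(-c3ccc(Cl)cc3)cc2-c2ccccc2)cc(OC)c1OC` gives 140 nM in this assay

Compound 3 differs from compound 1 by 4-chlorophenyl in place of 3-chlorophenyl on an aromatic nitrogen. Compound 4 `COc1cc(C(=O)c2cn(-c3ccc(Br)cc3)cc2-c2ccccc2)cc(OC)c1OC` is not yet measured; it differs from compound 3 by bromo in place of chloro on an aromatic carbon. The change from compound 1 to compound 2 is bromo in place of chloro on an aromatic carbon, and the step it made was a 1.9-fold lower number from compound 1 to compound 2 (0.28 log units; within the scatter). The two changes are of the same kind, not the same: in compound 2 the bromo stands meta to a large group, in compound 4 para to a large group. The step from compound 3 to compound 4 is expected to be a 1.6-fold lower number from compound 3 to compound 4 (0.22 log units; within the scatter), resting on compound 1 and compound 2, which show a 1.9-fold lower number from compound 1 to compound 2 (0.28 log units; within the scatter). Compound 4 is estimated at 85 nM, between 40 nM and 180 nM.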

Compound 4, half-maximal inhibitory concentration: 20 nM
Compound 4: the middle estimate sits 4.3-fold (0.63 log units) above what was measured; the measured number lies below the stated range.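

Bromo in place of chloro does not carry over as a fixed step between the two cores in this assay: the same change on two cores in this assay, a 1.9-fold lower number (0.28 log units; within the scatter) from compound 1 to compound 2 and a 7.0-fold lower number (0.85 log units; beyond the scatter) from compound 3 to compound 4, 3.6-fold (0.56 log units) apart, beyond the scatter of two such steps

With 4-bromophenyl in place of 4-chlorophenyl the swap gives a 7.0-fold lower number from compound 3 to compound 4 (0.85 log units; beyond the scatter), and the other two steps into the same compound are a 3.9-fold lower number from compound 2 to compound 4 (0.59 log units; beyond the scatter) and a 7.5-fold lower number from compound 1 to compound 4 (0.88 log units; beyond the scatter), which makes compound 4 the strongest of the four. Two pairs in a single cell assay do not show why the steps differ, nor how the swap would behave on any further core.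

As far as these compounds go, whether an iodo, a fluoro or a methoxy group in that place would match or pass the bromo of compound 4 remains open. From the compounds shown here alone, an amine there remains equally open.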